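Ethyl on the carbamoyl nitrogen of the methoxybenzyl triazole

This account rests on a few compounds, and the source may have more. Where it says the series, first, only, none or still open, it means among the compounds named here.

Of the compounds shown here, two have been tested in a functional assay on SMMC-7721 cells (Homo sapiens) for cytotoxicity, read by MTT assay, with a stated time of 72 h; a higher number here means a weaker inhibitor, a lower number a stronger inhibitor. Compound 1 `CCNC(=O)N1CCN(C(=S)SCc2cn(Cc3ccc(F)cc3)nn2)CC1` carries an ethylcarbamoyl group on its piperazine and a fluorobenzyl group on its triazole; in this assay compound 1 gives 44400 nM. Compound 2 `COc1ccc(Cn2cc(CSC(=S)N3CCN(C(N)=O)CC3)nn2)cc1` carries a plain carbamoyl group and a methoxybenzyl group. For compound 2 this assay reports only a limit, > 128000 nM, so compound 2 stands at the weak end of the two values, at the point described by the limit of > 128000 nM in this assay, at which 1 of the 2 values shown sits, and no number is known for it.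

Compound 3 `CCNC(=O)N1CCN(C(=S)SCc2cn(Cc3ccc(OC)cc3)nn2)CC1` is the next member. It differs from compound 2 in one place: ethyl in place of hydrogen on an amide-type nitrogen. Among the measured compounds shown here, no measured pair shows this change on its own. Compound 1, which already bears the ethyl group, sits at a lower number than the limit reported for compound 2, and on that basis the step from compound 2 to compound 3 is expected to move toward a lower number, as an at least 1.4-fold lower number from compound 2 to compound 3 (0.15 log units; that floor lies within the scatter), though with a fair chance that only a limit is returned again. Compound 3 is therefore estimated at 90000 nM, with a range from 35000 nM to 200000 nM.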

Compound 3, half-maximal inhibitory concentration: > 128000 nM
Compound 3 gave a limit, no number (the forecaster's own chance of this, stated with the estimate: 45%); middle value at least 1.4-fold (0.15 log units) away from the limit.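

In this assay, among the compounds shown here, methoxy in place of fluoro on an aromatic carbon, with the ethylcarbamoyl group held the same, gives an at least 2.8-fold higher number from compound 1 to compound 3 (0.45 log units; beyond the scatter), the first reading of this change on its own. The step for ethyl in place of hydrogen on the amide-type nitrogen cannot be read, as both of its ends are limits and not numbers: the limit of > 128000 nM in this assay, at which 2 of the 3 values shown sit. Among the three compounds, the ethyl group on this nitrogen does not by itself bring a methoxy compound to a measured number in this assay, and only compound 1, with fluoro, has one.

On these data alone, the true positions of compound 2 and compound 3 remain unknown, so the full size of the methoxy step and any effect of the ethyl group in the methoxy pair stay open. The compounds shown also leave open whether the ethyl step could be read with fluoro on the aromatic carbon, and how chloro at that place or a propyl chain on the amide-type nitrogen would stand in this assay.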